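Chain length at the ether oxygen

A few compounds are considered here, and "the series" means these few. Any claim that something is new, unique, unknown or untested is made for them only; others in the source may bear on it.

Measured so far:
Compound 1 `CC(C)COc1ccc2c(Cl)ccnc2c1`: 3030 nM
Compound 2 `CCCCCCCCOc1ccc2c(Cl)ccnc2c1`: 4300 nM
Compound 3 `CN(C)CCNc1ccnc2cc(OCc3ccccc3)ccc12`: 1250 nM

In a functional assay on BGC-823 cells (Homo sapiens) for cytotoxicity, read by MTT assay, with a stated time of 48 h (a lower number here means a stronger inhibitor, a higher number a weaker inhibitor), compound 2 gives the highest of the three numbers. Its gap to compound 1 lies within the scatter; compound 3 sits beyond the scatter with the lower number. Compound 4 `CCOc1ccc2c(Cl)ccnc2c1` has not been measured. It differs from compound 2 by hydrogen in place of hexyl on a saturated chain carbon, two bonds along the chain from an oxygen on an aromatic ring. Within the data shown here, no step between measured compounds covers a change of this kind; the pair of compound 1 and compound 2 shows only that an isobutyl and an octyl chain give numbers within the scatter of each other. The expected step from compound 2 to compound 4 is therefore a 1.1-fold lower number from compound 2 to compound 4 (0.03 log units; within the scatter), not beyond the scatter. Compound 4 is estimated at 4000 nM, with a range of 1500 nM to 11000 nM.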

Compound 4, half-maximal inhibitory concentration: 3910 nM
Compound 4: the middle estimate sits 1.0-fold (0.01 log units) above what was measured; the range from low to high includes it.
By their numbers in this assay, from the lowest: compound 3; then compounds 1, 4 and 2 (each within the scatter of the next).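

In this assay, hydrogen in place of hexyl keeps the number within the scatter (a 1.1-fold lower number from compound 2 to compound 4 (0.04 log units; within the scatter)), and methyl in place of isopropyl does the same (a 1.3-fold higher number from compound 1 to compound 4 (0.11 log units; within the scatter)). At this position, neither removing the chain length of compound 2 nor removing the branch of compound 1 separates either compound from compound 4. Nothing on hand explains this flat result.

On these data alone, whether an amine or a carboxylic acid on this chain would move the number beyond the scatter remains open. Compound 3 (1250 nM) differs from these ethers in more than one place, so its value cannot be assigned to any single change.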